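Acetylating the aryl amine of compound 2

The compounds below may be only part of what the source reports. "The series", "measured", "known", "first", "only" and "open" are said of these compounds alone.

Compound 2 `COc1cc(N)c(Cl)cc1C(=O)CCC1CCN(CCNS(=O)(=O)c2ccc(N)cc2)CC1` is the weaker of the two compounds measured in an assay on HEK293 cells for displacement of a labelled ligand from 5-hydroxytryptamine receptor 6 (Homo sapiens), with a stated time of 60 min, tested at 0.01 uM, in the presence of a further agent that is not named here; a lower number here means a weaker effect, a higher number a stronger effect of the compound at the concentration tested: compound 2 gives 7%, whereas compound 1 `COc1ccc(S(=O)(=O)NCCN2CCC(CCC(=O)c3cc(Cl)c(N)cc3OC)CC2)cc1Cl` gives 20%. Among the compounds with values here, the one measured step, a number 13 percentage points lower from compound 1 to compound 2 (beyond the scatter), concerns the aryl group on the sulfonyl sulfur and not the substitution of its amino nitrogen. Compound 3 `COc1cc(N)c(Cl)cc1C(=O)CCC1CCN(CCNS(=O)(=O)c2ccc(NC(C)=O)cc2)CC1` differs from compound 2 by acetyl in place of hydrogen on a nitrogen on an aromatic ring. Within the data shown here, no measured pair changes a substituent on that nitrogen, so the step from compound 1 to compound 2 gives only indirect guidance: changes at the sulfonyl aryl end shifted the read-out by a modest amount. With compound 2 already near the bottom of the range, compound 3 is expected to remain within the scatter of compound 2, a number 1 percentage points higher from compound 2 to compound 3 (within the scatter). Compound 3 is therefore estimated at 8%, with a range from 0% to 22%.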

Compound 3, a percentage reported as inhibition, at one concentration (the size of the read-out at that concentration, not a potency): 7%
Estimate against measurement, compound 3: 1 percentage points above; the measured number falls inside the stated range.
By their numbers in this assay, from the lowest: compounds 2 and 3 (each within the scatter of the next); then compound 1.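

In this assay, within the data shown here, acetyl on the nitrogen on the aromatic ring gives no change at the digits printed from compound 2 to compound 3 (within the scatter), the first measured change at that nitrogen, so at the one concentration tested this substituent does not separate the two compounds. The step of a number 13 percentage points lower from compound 1 to compound 3 (beyond the scatter) places the 4-acetamidophenyl group on the sulfonyl sulfur beyond the scatter from 3-chloro-4-methoxyphenyl, as 4-aminophenyl already was, and so the gap to compound 1 remains with either group on that nitrogen. No measurement offered here accounts for this result.

On these data alone, it remains open whether a longer acyl chain, a methanesulfonyl group or a dimethylamino group at that place would shift the read-out. A single concentration also leaves open whether compound 2 and compound 3 would stay level at higher concentrations.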